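From 4-cyanobenzyl to 4-(ethylsulfonyl)benzyl

The source may hold more compounds than are shown below. What is called first, only, known or untested is meant among the compounds shown, and "the series" means these compounds.

In an ADME assay on microsomes from liver (Homo sapiens) for metabolic stability, with a stated time of 10 min (a higher number here means that more of the compound is left, a lower number that less of the compound is left), compound 1 (`COc1ccc(CNC(=O)N2C[C@@H](c3ccc(C(O)(C(F)(F)F)C(F)(F)F)cc3)[C@@](C)(c3ccc(F)cc3)C2)cc1`) gives 68% while compound 2 (`C[C@]1(c2ccc(F)cc2)CN(C(=O)NCc2ccc(C#N)cc2)C[C@H]1c1ccc(C(O)(C(F)(F)F)C(F)(F)F)cc1`) gives 76% as its reading, level with compound 1 within the scatter. Compound 3 (`CCS(=O)(=O)c1ccc(CNC(=O)N2C[C@@H](c3ccc(C(O)(C(F)(F)F)C(F)(F)F)cc3)[C@@](C)(c3ccc(F)cc3)C2)cc1`) carries ethylsulfonyl in place of cyano on an aromatic carbon, para to a large group (ethylsulfonyl in place of cyano on an aromatic carbon). Among the compounds with values here, the one measured step at that place is a number 8 percentage points higher from compound 1 to compound 2 (within the scatter) with cyano in place of methoxy, and it stays within the scatter. Ethylsulfonyl itself is untested, so no step beyond the scatter is expected in this assay and the estimate is a number 4 percentage points lower from compound 2 to compound 3 (within the scatter) for this change. Compound 3 is estimated at 72% with 55% to 86% as its expected range.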

Compound 3, percent of the compound remaining: 32%
Beside the measured number, compound 3's estimate is 40 percentage points above it; measured number outside the range, below it.
By their numbers in this assay, from the lowest: compound 3; then compounds 1 and 2 (each within the scatter of the next).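

In this assay this position proves sensitive to the group it carries. Ethylsulfonyl gives a number 44 percentage points lower from compound 2 to compound 3 (beyond the scatter) and also a number 36 percentage points lower from compound 1 to compound 3 (beyond the scatter), whereas the earlier swap of methoxy for cyano stayed within the scatter. No measurement at hand says why the number falls. Open, from the compounds shown here alone, is whether the loss follows the sulfonyl unit itself or the ethyl chain on it. Methylsulfonyl, or a sulfonamide in the same place, would help to separate the two.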